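Ring Size Swap on the Ester Chain and L6 Cytotoxicity

A few compounds are considered here, and "the series" means these few. Any claim that something is new, unique, unknown or untested is made for them only; others in the source may bear on it.

Compound 1 `O=C(CN1CCCC1)OC1CC2(N3CCCC3)CC(c3ccccc3)C1C(c1ccccc1)C2`: 42900 nM
Compound 2 `O=C(CN1CCCCC1)OC1CC2(N3CCCC3)CC(c3ccccc3)C1C(c1ccccc1)C2`: 14200 nM
Compound 3 `CN(C)C12CC(OC(=O)CCN3CCCC3)C(C(c3ccccc3)C1)C(c1ccccc1)C2`: 26000 nM

Of the compounds shown here, three have been tested in an ADME assay on L6 cells (Rattus norvegicus) for cytotoxicity (a lower number here means a stronger inhibitor, a higher number a weaker inhibitor), and a fourth awaits its measurement. Compound 1 `O=C(CN1CCCC1)OC1CC2(N3CCCC3)CC(c3ccccc3)C1C(c1ccccc1)C2` and compound 2 `O=C(CN1CCCCC1)OC1CC2(N3CCCC3)CC(c3ccccc3)C1C(c1ccccc1)C2` share one core and differ only in the amine ring on the ester chain: piperidin-1-yl in place of pyrrolidin-1-yl on a saturated chain carbon bound to a carbonyl carbon. In this assay that change gave a 3.0-fold lower number from compound 1 to compound 2 (0.48 log units; beyond the scatter).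

Compound 3 `CN(C)C12CC(OC(=O)CCN3CCCC3)C(C(c3ccccc3)C1)C(c1ccccc1)C2` has a different core, and the difference between the two cores is not broken down here. In this assay compound 3 gives 26000 nM, a number within the scatter of compound 1 and of compound 2.

The unmeasured compound 4 `CN(C)C12CC(OC(=O)CCN3CCCCC3)C(C(c3ccccc3)C1)C(c1ccccc1)C2` is related to compound 3 by the same kind of change: piperidin-1-yl in place of pyrrolidin-1-yl on a saturated chain carbon, two bonds along the chain from a carbonyl carbon. The place is not identical, since in compound 1 and compound 2 the ring sits on a saturated chain carbon bound to a carbonyl carbon, whereas in compound 3 and compound 4 it sits on a saturated chain carbon two bonds along the chain from a carbonyl carbon.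

Because the earlier step was a 3.0-fold lower number from compound 1 to compound 2 (0.48 log units; beyond the scatter), a step of similar direction is expected here, though somewhat smaller given the different core and the longer chain; the expected step from compound 3 to compound 4 is a 2.4-fold lower number from compound 3 to compound 4 (0.37 log units; beyond the scatter). Compound 4 is therefore estimated to give 11000 nM in this assay, with a likely range from 5000 nM to 24000 nM.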

Compound 4, half-maximal inhibitory concentration: 25800 nM
Beside the measured number, compound 4's estimate is 2.3-fold (0.37 log units) below it, outside the stated range (above it).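

In this assay, piperidin-1-yl in place of pyrrolidin-1-yl on a saturated chain carbon, two bonds along the chain from a carbonyl carbon, gave a 1.0-fold lower number from compound 3 to compound 4 (0.00 log units; within the scatter), so the ring swap leaves no readable mark on this core. Set beside the earlier pair, the same swap did not carry over from one core to the other with the same size: the same change on two cores in this assay, a 3.0-fold lower number (0.48 log units; beyond the scatter) from compound 1 to compound 2 and a 1.0-fold lower number (0.00 log units; within the scatter) from compound 3 to compound 4, 3.0-fold (0.48 log units) apart, beyond the scatter of two such steps. The step seen on the core of compound 1 therefore cannot serve as a rule for the series, but the result does not show what sets the two pairs apart, as they differ both in the core and in where the ring sits on the chain, and two pairs cannot separate these two differences.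

The compounds shown leave open whether the ring on a longer chain on the core of compound 1, or on a shorter chain on the core of compound 3, would give a step like either of these. They also leave open how a morpholine ring, an azepane ring or an open-chain amine such as diethylamino would read in this assay at the same place on the chain.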